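A few compounds are considered here, and "the series" means these few. Any claim that something is new, unique, unknown or untested is made for them only; others in the source may bear on it.

Of the compounds shown here, three built on one shared core have been tested in an ADME assay on microsomes from liver (Homo sapiens) for pharmacokinetics; a lower number here means slower removal, a higher number faster removal of the compound. Compound 1 `Cc1nn(C2COC2)cc1Nc1nc(N)c2c(C#N)c(N3CCC[C@H]3C)n(C)c2n1` gives 46.7 mL/min/kg in this assay. Compound 2 `Cc1nn(CC(C)(C)O)cc1Nc1nc(N)c2c(C#N)c(N3CCC[C@H]3C)n(C)c2n1` differs from compound 1 by 2-hydroxy-2-methylpropyl in place of oxetan-3-yl on an aromatic nitrogen; in this assay compound 2 gives 50 mL/min/kg, and a 1.1-fold higher number from compound 1 to compound 2 (0.03 log units; within the scatter). Compound 3 `Cc1c(Nc2nc(N)c3c(C#N)c(N4CCC[C@H]4C)n(C)c3n2)cnn1C1COC1` differs from compound 1 by 5-methyl-1-(oxetan-3-yl)-1H-pyrazol-4-yl in place of 3-methyl-1-(oxetan-3-yl)-1H-pyrazol-4-yl on a nitrogen on an aromatic ring; in this assay compound 3 gives 14.3 mL/min/kg, and a 3.3-fold lower number from compound 1 to compound 3 (0.51 log units; beyond the scatter). Compound 4 `Cc1c(Nc2nc(N)c3c(C#N)c(N4CCC[C@H]4C)n(C)c3n2)cnn1CC(C)(C)O` has not yet been measured. It differs from compound 3 by 2-hydroxy-2-methylpropyl in place of oxetan-3-yl on an aromatic nitrogen. Going by the values given here, this is the same kind of change as the one from compound 1 to compound 2, but the surroundings are not identical: in compound 3 the aromatic nitrogen carrying the group is next to the ring atom that bears a methyl group and two ring bonds from the ring atom that bears a large group, whereas in compound 1 it is two ring bonds from each of them. Because the earlier step of a 1.1-fold higher number from compound 1 to compound 2 (0.03 log units; within the scatter) stayed within the scatter, a similarly small step is expected for compound 4, namely a 1.1-fold higher number from compound 3 to compound 4 (0.05 log units; within the scatter). In this assay compound 4 is therefore estimated at 16 mL/min/kg, with a likely range from 9 mL/min/kg to 30 mL/min/kg.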

Compound 4, clearance: 30 mL/min/kg
For compound 4 the middle estimate is 1.9-fold (0.27 log units) below the measured one; the measured number falls inside the stated range.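

In this assay, putting 2-hydroxy-2-methylpropyl in place of oxetan-3-yl on the aromatic nitrogen gives a 2.1-fold higher number from compound 3 to compound 4 (0.32 log units; beyond the scatter), a modest step on its own. Set beside the same change on the other core, this step cannot be told apart from the earlier one, since the gap between them is no larger than repeated measurements could produce: the same change on two cores in this assay, a 1.1-fold higher number (0.03 log units; within the scatter) from compound 1 to compound 2 and a 2.1-fold higher number (0.32 log units; beyond the scatter) from compound 3 to compound 4, 2.0-fold (0.29 log units) apart, within the scatter of two such steps. Going by these compounds alone, this shows that, so far, nothing separates the effect of the change on these two cores, but it does not show that the effect is truly the same, since each core offers only a single pair of compounds, and two pairs make no rule for any further core.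

The compounds shown carry only these two groups on that aromatic nitrogen, so it remains open how a plain methyl, a longer chain ending in a hydroxyl, or an amine such as azetidin-3-yl would behave in this assay. From the compounds shown here alone, it also remains open whether the step would hold if the methyl group on the ring gave way to an ethyl group or a chlorine atom.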